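Bare ring nitrogen in place of the 2-fluorophenyl arm

This account rests on a few compounds, and the source may have more. Where it says the series, first, only, none or still open, it means among the compounds named here.

Compound 1 `Cc1cc(=O)oc2cc(OCc3cn(-c4ccccc4F)nn3)ccc12` is the reference point of this small set. In an ADME assay on Huh-7 cells (Homo sapiens) for cytotoxicity, read by MTT assay, with a stated time of 72 h (a higher number here means that more compound is tolerated, a lower number that less compound is tolerated), compound 1 gives > 100 ug/mL, which is a limit of the assay and not a number. Compound 2 `COc1cc(-n2cc(COc3ccc4c(C)cc(=O)oc4c3)nn2)cc(OC)c1OC` in this assay gives > 100 ug/mL, again only a limit. Compound 3 `COC(=O)Cn1cc(COc2ccc3c(C)cc(=O)oc3c2)nn1` in this assay gives > 100 ug/mL, once more a limit. Going by the values given here, the one single-point step that has been measured, a step that the two limits leave unreadable from compound 1 to compound 3, therefore cannot be read in size or direction, since both of its ends are limits; all three values sit at the limit of > 100 ug/mL in this assay, at which 3 of the 3 values shown sit.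

Compound 4 `Cc1cc(=O)oc2cc(OCc3c[nH]nn3)ccc12` differs from compound 1 as follows: hydrogen in place of 2-fluorophenyl on an aromatic nitrogen. The step that bears on this change is a step that the two limits leave unreadable from compound 1 to compound 3, a replacement on the same aromatic nitrogen that left the value at the limit, so no step beyond the scatter is expected here. Compound 4 is expected to give 150 ug/mL, within 70 ug/mL to 400 ug/mL, most probably reported as a limit only. The step that the limit leaves unreadable from compound 1 to compound 4 is accordingly estimated to be flat.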

Compound 4, half-maximal cytotoxic concentration: > 100 ug/mL
Compound 4 ended at the assay's limit; the forecaster's own chance of this, stated with the estimate: 80%; the middle value does not contradict the limit.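

Compound 4 also sits at a limit, so the steps to it from compound 1 and compound 3 cannot be read: the limit of > 100 ug/mL in this assay, at which 4 of the 4 values shown sit.

The compounds shown leave open whether any group on the aromatic nitrogen would give a readable value in this assay.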